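The source may hold more compounds than are shown below. What is called first, only, known or untested is meant among the compounds shown, and "the series" means these compounds.

Measured compounds:
- Compound 1, `O=C(O)CCCc1ccc(NCc2cccc(Oc3ccccc3)c2)cc1`, in a functional assay on CHO cells for agonist activity at Free fatty acid receptor 1 (Homo sapiens) (a lower number here means that less compound is needed, a higher number that more compound is needed for the effect), compound 1 gives 1120 nM
- Compound 2, `O=C(O)COc1ccc(NCc2cccc(Oc3ccccc3)c2)cc1`, compound 2 gives 2040 nM
- Compound 3, `CC(CC(=O)O)c1ccc(NCc2cccc(Oc3ccccc3)c2)cc1`, compound 3 gives 126 nM

Compound 3 stands lowest of the three, and its steps to both others lie beyond the scatter, so it is the most potent of the set: an 8.9-fold lower number from compound 1 to compound 3 (0.95 log units; beyond the scatter) and a 16-fold lower number from compound 2 to compound 3 (1.21 log units; beyond the scatter). The step between the two weaker compounds, a 1.8-fold higher number from compound 1 to compound 2 (0.26 log units; within the scatter), is within the scatter.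

Compound 4, `CN(C)C(=O)CCc1ccc(NCc2cccc(Oc3ccccc3)c2)cc1`, is not yet measured. It differs from compound 3 in one place: 2-(dimethylcarbamoyl)ethyl in place of 1-(carboxymethyl)ethyl on an aromatic carbon. Every measured compound carries a carboxylic acid, and the measured steps only swap one acid-bearing chain for another; none removes the acid. Within the data shown here, no measured step therefore bears directly on this change. The expected step from compound 3 to compound 4 is a 40-fold higher number from compound 3 to compound 4 (1.60 log units; beyond the scatter), toward a higher number, with wide uncertainty. The estimate for compound 4 in this assay is 5000 nM, expected between 800 nM and 30000 nM.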

Compound 4, half-maximal effective concentration: 174 nM
Compound 4: middle estimate off by 29-fold (1.46 log units), on the high side, outside the stated range (below it).
By their numbers in this assay, from the lowest: compounds 3 and 4 (each within the scatter of the next); then compounds 1 and 2 (each within the scatter of the next).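

In this assay, compound 4 shows that this position does not need a carboxylic acid to give a low number: replacing 1-(carboxymethyl)ethyl with 2-(dimethylcarbamoyl)ethyl, which has no hydrogen-bond donor, gives a 1.4-fold higher number from compound 3 to compound 4 (0.14 log units; within the scatter) and leaves the two compounds indistinguishable. The amide also compares well with the other two acids, with a 12-fold lower number from compound 2 to compound 4 (1.07 log units; beyond the scatter) and a 6.4-fold lower number from compound 1 to compound 4 (0.81 log units; beyond the scatter), so an acid on this chain does not by itself set the number here: compound 1 and compound 2 carry one and give higher numbers, while compound 3 carries one and does not. No supporting measurement explains why this swap changes so little.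

From the compounds shown here alone, this change alters both the branching and the chain end, so the contribution of each remains open. A 2-carboxyethyl chain would separate the two, and a primary amide or an amine at the chain end would test how far this tolerance extends.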